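This account rests on a few compounds, and the source may have more. Where it says the series, first, only, none or still open, it means among the compounds named here.

Measured compounds:
compound 1 `CNC(=O)c1cnc(N2CCN(C3CCN(Cc4ccccn4)CC3)[C@@H](C)C2)c(Cl)c1`, 7990 nM
compound 2 `CNC(=O)c1cnc(N2CCN(C3CCN(C(F)(F)F)CC3)[C@@H](C)C2)c(Cl)c1`, 63 nM

Within the data shown here, in a functional assay for antagonist activity at C-X-C chemokine receptor type 3 (Homo sapiens) (a higher number here means a weaker inhibitor, a lower number a stronger inhibitor), compound 2 holds the lower of the two numbers, and the only step to it, a 130-fold lower number from compound 1 to compound 2 (2.10 log units; beyond the scatter), is large. Compound 3 `CNC(=O)c1cnc(N2CCN(C3CCN(Cc4ccc(Cl)cc4F)CC3)[C@@H](C)C2)c(Cl)c1` turns back toward the shape of compound 1: 4-chloro-2-fluorobenzyl in place of trifluoromethyl on an amine nitrogen in a ring. Among the measured compounds shown here, the one step that bears on it, a 130-fold lower number from compound 1 to compound 2 (2.10 log units; beyond the scatter), shows how much an arylmethyl group on that nitrogen cost against trifluoromethyl, so a sizeable rise is expected, though the halogenated benzyl need not match the pyridin-2-ylmethyl outcome exactly. Compound 3 is therefore estimated at 1500 nM, within 250 nM to 9000 nM, a change of a 24-fold higher number from compound 2 to compound 3 (1.38 log units; beyond the scatter).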

Compound 3, half-maximal inhibitory concentration: 18 nM
Compound 3: middle estimate off by 83-fold (1.92 log units), on the high side, outside the stated range (below it).
By their numbers in this assay, from the lowest: compound 3; then compound 2; then compound 1.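

In this assay, an arylmethyl group on this amine nitrogen proves no liability in itself: a 3.5-fold lower number from compound 2 to compound 3 (0.54 log units; beyond the scatter), and a 440-fold lower number from compound 1 to compound 3 (2.65 log units; beyond the scatter). The result at this position therefore depends heavily on the aromatic ring the group carries, and not merely on the presence of an arylmethyl group. On these data alone, whether the chlorine, the fluorine or the carbon-only ring accounts for the gain remains open, as does how an unsubstituted benzyl or a cyclohexylmethyl group would fare on this nitrogen. No evidence is available to explain these differences.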